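A pyridin-2-yl swap at the solubility limit

This account rests on a few compounds, and the source may have more. Where it says the series, first, only, none or still open, it means among the compounds named here.

Compound 1 `O=C(NCCCCc1ccccc1)n1cc(-c2ccccc2)oc1=O`: < 1000 nM, a limit
Compound 2 `CCCCCNC(=O)n1cc(-c2ccccc2)oc1=O`: < 1000 nM, a limit

In a physicochemical assay for solubility, read by HPLC, in phosphate buffer, measured as kinetic solubility, with a stated time of 1 h, at pH 7.4, tested at 250 uM (a higher number here means a more soluble compound, a lower number a less soluble compound), compound 1 stands only at a limit, < 1000 nM. Compound 2 likewise gives only a limit, < 1000 nM. The record so far therefore holds no numerical value, only (the limit of < 1000 nM in this assay, at which 2 of the 2 values shown sit).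

Compound 3 `O=C(NCCCCc1ccccc1)n1cc(-c2ccccn2)oc1=O` has not yet been measured. It differs from compound 1 by one change: pyridin-2-yl in place of phenyl on an aromatic carbon. In words, pyridin-2-yl stands in place of phenyl on an aromatic carbon.

Among the measured compounds shown here, the only measured step is a step that the two limits leave unreadable from compound 1 to compound 2, and it makes a different change and offers no size to carry over. No step beyond the scatter is therefore expected, in either direction. The expected step is a step that the limit leaves unreadable from compound 1 to compound 3. For compound 3 the estimate is 800 nM, with an expected range of 300 nM to 3000 nM.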

Compound 3, solubility: < 1000 nM
Compound 3 gave a limit, no number; the forecaster's own chance of this, stated with the estimate: 70%; the middle value is on the limit's open side.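

Among the compounds shown here, compound 1 and compound 3 both stand only at a limit, so no step between them can be read. The compounds shown leave open how soluble each one actually is, and whether pyridin-2-yl in place of phenyl changes the read-out at all: the limit of < 1000 nM in this assay, at which 3 of the 3 values shown sit.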